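A few compounds are considered here, and "the series" means these few. Any claim that something is new, unique, unknown or untested is made for them only; others in the source may bear on it.

Of the compounds shown here, three have been measured in a functional assay on A549 cells (Homo sapiens) for inhibition, read by MTT assay, with a stated time of 72 h (on this read-out lower numbers stand for stronger inhibition and higher numbers for weaker inhibition), all built on a shared core that carries a saturated nitrogen ring on one aromatic carbon. Compound 2 `CNC(=O)c1cc(Oc2ccc(Nc3nccc(N4CCCCC4)n3)cc2)ccn1` gives 890 nM in this assay. Compound 1 `CNC(=O)c1cc(Oc2ccc(Nc3nccc(N4CCCC4)n3)cc2)ccn1` differs from it by pyrrolidin-1-yl in place of piperidin-1-yl on an aromatic carbon and gives 3410 nM; that change produces a 3.8-fold higher number from compound 2 to compound 1 (0.58 log units; beyond the scatter). Compound 3 `c1cc(N2CCCCC2)nc(Nc2ccc(Oc3ncnc4ccsc34)cc2)n1` keeps the piperidin-1-yl of compound 2 but has a different core, and the difference between the two cores is a group of 9 heavy atoms (6 carbon, 2 nitrogen, 1 sulfur; one five-membered aromatic ring with 1 hetero atom, one six-membered aromatic ring with 2 hetero atoms) in place of a group of 10 heavy atoms (7 carbon, 2 nitrogen, 1 oxygen; one six-membered aromatic ring with 1 hetero atom), on an oxygen on an aromatic ring. In this assay compound 3 gives 7800 nM, the step being an 8.8-fold higher number from compound 2 to compound 3 (0.94 log units; beyond the scatter), which leaves compound 3 with the highest number of the three.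

Compound 4 `c1cc(N2CCCC2)nc(Nc2ccc(Oc3ncnc4ccsc34)cc2)n1` has not yet been measured. It differs from compound 3 by pyrrolidin-1-yl in place of piperidin-1-yl on an aromatic carbon. This is the same change that separates compound 1 from compound 2, occurring twice among the compounds shown, and in both pairs it sits on an aromatic carbon of a six-membered aromatic ring with 2 nitrogen, the places being described in identical terms. The same step, seen earlier as a 3.8-fold higher number from compound 2 to compound 1 (0.58 log units; beyond the scatter), is expected to recur here, giving an estimated 3.2-fold higher number from compound 3 to compound 4 (0.51 log units; beyond the scatter); this expectation rests on a single measured pair and on a core that is not the same, so it is held loosely. Compound 4 is therefore expected to give about 25000 nM in this assay, with a likely range from 10000 nM to 60000 nM.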

Compound 4, half-maximal inhibitory concentration: "not active" (no number reported)
No number was reported for compound 4; there is nothing to compare the estimate with.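

Within the data shown here, compound 4 is reported as not active in this assay with no number given, so no step from compound 3 to compound 4 can be read. The compounds shown leave open whether pyrrolidin-1-yl in place of piperidin-1-yl changes the read-out on the core of compound 3 as it does on the core of compound 2. Nothing shown offers an explanation for this result.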